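Swapping the group on the ring nitrogen of a shared core

The compounds below may be only part of what the source reports. "The series", "measured", "known", "first", "only" and "open" are said of these compounds alone.

Compound 1 `O=[N+]([O-])c1cc(CSc2nnc(-c3ccccc3)n2C2CCCCC2)cc([N+](=O)[O-])c1`: in an ADME assay on A-431 cells (Homo sapiens) for cytotoxicity, with a stated time of 48 h (on this read-out lower numbers stand for stronger inhibition and higher numbers for weaker inhibition), compound 1 gives > 30000 nM, which is a limit of the assay and not a number.
Compound 2 `COc1ccc(Cn2c(SCc3cc([N+](=O)[O-])cc([N+](=O)[O-])c3)nnc2-c2ccccc2)cc1`: in this assay compound 2 gives > 30000 nM, again a limit rather than a number.

Compound 2 thus stands at the limit of this assay, with no numerical value to place it. Going by the values given here, the only measured change, a step that the two limits leave unreadable from compound 1 to compound 2, cannot be read, because the limit of > 30000 nM in this assay, at which 2 of the 2 values shown sit, shows that both values sit at that same limit. The next change, (3,4-dichlorophenyl in place of 4-methoxybenzyl on an aromatic nitrogen), leads to compound 3 `O=[N+]([O-])c1cc(CSc2nnc(-c3ccccc3)n2-c2ccc(Cl)c(Cl)c2)cc([N+](=O)[O-])c1`. No readable measured step bears on this change, so there is no ground to expect a step of any size or direction beyond the scatter, and the most likely outcome is that compound 3 also returns only a limit. For compound 3 the estimated value is 50000 nM, expected to lie between 10000 nM and 200000 nM. The step this estimate implies, a step that the limit leaves unreadable from compound 2 to compound 3, is expected to be unreadable against the limit.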

Compound 3, half-maximal inhibitory concentration: > 30000 nM
Compound 3 was reported as a limit; the forecaster's own chance of this, stated with the estimate: 85%; the middle value is on the limit's open side.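

No step from compound 2 to compound 3, or from compound 1 to compound 3, can be read, because all three compounds sit at the same limit rather than at a number: the limit of > 30000 nM in this assay, at which 3 of the 3 values shown sit.

The compounds shown leave open whether cyclohexyl, 4-methoxybenzyl and 3,4-dichlorophenyl on the aromatic nitrogen differ at all in this assay.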